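Phenyl in place of methylamino: cytotoxicity notes

A few compounds are considered here, and "the series" means these few. Any claim that something is new, unique, unknown or untested is made for them only; others in the source may bear on it.

In a toxicity assay on THP-1 cells (Homo sapiens) for cytotoxicity (a higher number here means that more compound is needed for the effect, a lower number that less compound is needed), compound 2 (`CNc1ccnc2c(O)c(-c3nc(C)n[nH]3)ncc12`) gives > 50100 nM as a limit of the assay and not a number. Compound 1 (`O=C(NCc1ccc(Cl)cc1)c1ncc2cccnc2c1O`) gives > 50100 nM as a limit too. Compound 3 (`Cc1n[nH]c(-c2ncc3c(NCc4ccc(Cl)cc4)ccnc3c2O)n1`) likewise gives > 50100 nM as a limit. Compound 2 thus stands with the other two on the same reading: the limit of > 50100 nM in this assay, at which 3 of the 3 values shown sit.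

Compound 4 (`Cc1n[nH]c(-c2ncc3c(-c4ccccc4)ccnc3c2O)n1`) differs from compound 2 by phenyl in place of methylamino on an aromatic carbon, which puts phenyl in place of methylamino on an aromatic carbon, opposite the ring nitrogen. Within the data shown here, the only measured step that bears on this is a step that the two limits leave unreadable from compound 2 to compound 3, with 4-chlorophenyl in place of hydrogen on a saturated chain carbon bound to a nitrogen on an aromatic ring. Among the measured compounds shown here, it has no readable size, and no measured compound has left the limit. No step beyond the scatter is therefore expected in this assay, in either direction, though a reading inside the range of the assay remains possible. The expected step is a number no higher from compound 2 to compound 4 (the limit leaves the size open). For compound 4 the estimate is 50100 nM, with an expected range from 15000 nM to 100000 nM.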

Compound 4, half-maximal effective concentration in the THP-1 assay: > 50100 nM
Compound 4: no number, only a limit; the forecaster's own chance of this, stated with the estimate: 75%; the middle value sits exactly at the limit.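

In the THP-1 assay compound 2 gives > 50100 nM, a limit of the assay and not a number. In the THP-1 assay compound 4 gives > 50100 nM, again a limit of the assay and not a number. No step can be read from compound 2 to compound 4 in the THP-1 assay, since both readings are limits of the assay: the limit of > 50100 nM in the THP-1 assay, at which 4 of the 4 values shown sit.

The compounds shown leave open what size, if any, the change of phenyl in place of methylamino on an aromatic carbon has in the THP-1 assay, and at what concentration any of them reaches the effect.

In a physicochemical assay for solubility, measured as kinetic solubility (on this read-out lower numbers stand for lower solubility and higher numbers for higher solubility), compound 2 gives > 250000 nM, a limit of the assay and not a number. In the physicochemical assay compound 4 gives 160000 nM. The same change appears in the physicochemical assay as an at least 1.5-fold lower number from compound 2 to compound 4 (0.19 log units; that floor lies within the scatter).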